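Aryl change on the shared core: compound 2 to compound 3

The source may report more compounds than this note shows. Statements on the series, on what has been measured and on what is new or still open speak of the compounds shown alone.

- compound 1 `COc1ccc(C(F)(F)F)cc1Nc1ncc(C(F)(F)F)c(N2Cc3cccc(N(C)S(C)(=O)=O)c3C2)n1`: > 30000 nM (a limit of the assay)
- compound 2 `COc1cc(Nc2ncc(C(F)(F)F)c(N3Cc4cccc(N(C)S(C)(=O)=O)c4C3)n2)c(OC)cc1Cl`: 25600 nM

Going by the values given here, in a functional assay on HepG2 cells (Homo sapiens) for antiproliferative activity, read by spectrophotometry, with a stated time of 2 days (a lower number here means a stronger inhibitor of growth, a higher number a weaker inhibitor of growth), compound 2, at 25600 nM, holds the only actual number so far. The entry for compound 1, > 30000 nM, is a limit of the assay, as noted in the limit of > 30000 nM in this assay, at which 1 of the 2 values shown sits.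

Compound 3 `Cc1cc(F)ccc1Nc1ncc(C(F)(F)F)c(N2Cc3cccc(N(C)S(C)(=O)=O)c3C2)n1` carries 4-fluoro-2-methylphenyl in place of 4-chloro-2,5-dimethoxyphenyl on a nitrogen on an aromatic ring. The one measured step at this place is an at least 1.1-fold lower number from compound 1 to compound 2 (0.06 log units; that floor lies within the scatter), so a change of aryl group on that nitrogen has not yet shown a shift beyond the scatter. No clear shift in this assay is expected here. The expected step is a 1.0-fold higher number from compound 2 to compound 3 (0.01 log units; within the scatter), estimated to stay within the scatter. For compound 3 the estimated value is 26000 nM, with an expected range of 12000 nM to 55000 nM.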

Compound 3, concentration for 50% growth inhibition: 16800 nM
Compound 3: the middle estimate sits 1.5-fold (0.19 log units) above what was measured; measured number inside the range.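

In this assay, going by these compounds alone, the exchange of 4-chloro-2,5-dimethoxyphenyl for 4-fluoro-2-methylphenyl gives the first step at this nitrogen between two actual numbers: a 1.5-fold lower number from compound 2 to compound 3 (0.18 log units; within the scatter). The entering group lacks the hydrogen-bond acceptors of the group it replaces, yet the step stays within the scatter. The comparison with the third aryl group, an at least 1.7-fold lower number from compound 1 to compound 3 (0.25 log units; that floor lies within the scatter), gives only a floor: the limit of > 30000 nM in this assay, at which 1 of the 3 values shown sits.

As far as these compounds go, it remains open whether any aryl change on this nitrogen moves the number beyond the scatter. From the compounds shown here alone, how an amine or a carboxylic acid on the ring would read is also open.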